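This account rests on a few compounds, and the source may have more. Where it says the series, first, only, none or still open, it means among the compounds named here.

Compound 1 `O=C(C=C1CCN(C(=O)c2ccc(F)cc2)CC1)N[C@@H]1CCN(Cc2ccc3cc(F)ccc3c2)C1`: 237 mL/min/kg
Compound 2 `Cc1ccc(C(=O)N2CCC(=CC(=O)N[C@@H]3CCN(Cc4ccc5cc(F)ccc5c4)C3)CC2)c(O)c1`: 156 mL/min/kg
Compound 3 `COc1cccc(O)c1C(=O)N1CCC(=CC(=O)N[C@@H]2CCN(Cc3ccc4cc(F)ccc4c3)C2)CC1`: 192 mL/min/kg

In an in vitro ADME assay on microsomes from liver (Homo sapiens) for metabolic stability (on this read-out lower numbers stand for slow clearance and higher numbers for fast clearance), compound 3 gives 192 mL/min/kg, within the scatter of both other compounds. Compound 4 `COc1ccc(O)c(C(=O)N2CCC(=CC(=O)N[C@@H]3CCN(Cc4ccc5cc(F)ccc5c4)C3)CC2)c1` has the same atoms joined differently: 2-hydroxy-5-methoxyphenyl in place of 2-hydroxy-6-methoxyphenyl on a carbonyl carbon. The group on the carbonyl carbon is the only part that differs. The measured steps also change that group, and all are small: a 1.5-fold lower number from compound 1 to compound 2 (0.18 log units; within the scatter), a 1.2-fold lower number from compound 1 to compound 3 (0.09 log units; within the scatter) and a 1.2-fold higher number from compound 2 to compound 3 (0.09 log units; within the scatter). Each lies within the scatter, though none of them tests this exact swap, so the evidence is indirect. The expected change, a 1.1-fold lower number from compound 3 to compound 4 (0.03 log units; within the scatter), is therefore none beyond the scatter. Compound 4 is estimated at 180 mL/min/kg, with an expected range of 105 mL/min/kg to 290 mL/min/kg.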

Compound 4, clearance: 119 mL/min/kg
Estimate against measurement, compound 4: 1.5-fold (0.18 log units) above; the range from low to high includes it.
By their numbers in this assay, from the lowest: compounds 4, 2, 3 and 1 (each within the scatter of the next).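

Moving the methoxy group, with 2-hydroxy-5-methoxyphenyl in place of 2-hydroxy-6-methoxyphenyl on the carbonyl carbon, keeps the same atoms and only joins them differently, and in this assay this gives (  a 1.6-fold lower number from compound 3 to compound 4 (0.21 log units; within the scatter)  ). The other new steps (  a 1.3-fold lower number from compound 2 to compound 4 (0.12 log units; within the scatter)  ) and (  a 2.0-fold lower number from compound 1 to compound 4 (0.30 log units; within the scatter)  ) also stay within the scatter, so none of these four groups on the carbonyl carbon stands apart from the others.

On these data alone, whether an amine or a carboxylic acid in place of the methoxy group would move the number beyond the scatter stays open. No measured evidence here speaks to what lies behind these numbers.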